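The source may hold more compounds than are shown below. What is called first, only, known or untested is meant among the compounds shown, and "the series" means these compounds.

Among the measured compounds shown here, compound 1 `Cc1cc2cc(NS(=O)(=O)c3cc(C(=O)NO)ccc3Cl)ccc2n(C)c1=O` is one of two compounds measured in an assay on isolated protein for inhibition of protein deacetylase HDAC6 (Homo sapiens), read by fluorescence, with a stated time of 90 min, tested at 1 uM; on this read-out lower numbers stand for a weaker effect and higher numbers for a stronger effect at the one concentration tested. In this assay compound 1 gives 13%, the lower of the two numbers, while compound 2 `COc1ccc(C(=O)NO)cc1NCc1ccc(OCCCCC(=O)Nc2ccc3c(c2)cc(C)c(=O)n3C)cc1` gives 50%, a gap beyond the usual scatter. Compound 3 `COc1ccc(C(=O)NO)cc1S(=O)(=O)Nc1ccc2c(c1)cc(C)c(=O)n2C` has not yet been measured; it differs from compound 1 by methoxy in place of chloro on an aromatic carbon. For the measured compounds named here, no measured pair shows this change on its own, so the size of the step rests on expectation. A modest rise, at most at the edge of the scatter, is expected from compound 1 to compound 3 a number 9 percentage points higher from compound 1 to compound 3 (within the scatter). In this assay compound 3 is estimated at 22%, within 6% to 45%.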

Compound 3, a percentage reported as inhibition, at one concentration (the size of the read-out at that concentration, not a potency): 21%
The estimate for compound 3 lay 1 percentage points above the measured number, and the stated range covers the measured number.
By their numbers in this assay, from the lowest: compounds 1 and 3 (each within the scatter of the next); then compound 2.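

In this assay, among the compounds shown here, methoxy in place of chloro on the aromatic carbon para to a hydroxycarbamoyl group gives a number 8 percentage points higher from compound 1 to compound 3 (within the scatter) and this is the first measured pair showing this change on its own. At this position, the exchange therefore leaves the two compounds within the scatter of each other. Nothing available bears on why this is so.

Going by these compounds, whether an amine, a hydroxyl group or a longer alkoxy chain on this carbon would give a step beyond the scatter remains open. So does whether chloro in place of methoxy would give a similar step on compound 2.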